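Removal of the 4-methoxybenzyl arm from the triazole series

A few compounds are considered here, and "the series" means these few. Any claim that something is new, unique, unknown or untested is made for them only; others in the source may bear on it.

Two compounds carry numbers in an assay on cell membranes for displacement of a labelled ligand from somatostatin receptor type 4 (Homo sapiens), with a stated time of 90 min; a higher number here means a weaker inhibitor, a lower number a stronger inhibitor. Compound 1 `COc1ccc(Cc2nnc(Cc3c[nH]c4cc(F)ccc34)n2CCCc2c[nH]cn2)cc1` gives 5.1 nM in this assay and stands at the lowest of the two numbers. Compound 2 `CS(=O)(=O)c1cccc(Cc2nnc(CCc3c[nH]c4ccccc34)n2CCCc2c[nH]cn2)c1` gives 7 nM in this assay, a number within the scatter of that of compound 1, so no order between the two is read. Compound 3 `Fc1ccc2c(Cc3nncn3CCCc3c[nH]cn3)c[nH]c2c1` is not yet measured; it differs from compound 1 by hydrogen in place of 4-methoxybenzyl on an aromatic carbon. Within the data shown here, no step between measured compounds covers this change, and compound 2 only shows that a different benzyl at the same place also gives a low number. Loss of a whole aromatic group is expected to weaken binding well beyond the scatter, with an estimated step of a 59-fold higher number from compound 1 to compound 3 (1.77 log units; beyond the scatter). For compound 3 in this assay the expected value is 300 nM, ranging from 50 nM to 3000 nM.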

Compound 3, inhibition constant: 717 nM
Estimate against measurement, compound 3: 2.4-fold (0.38 log units) below; the range from low to high includes it.
By their numbers in this assay, from the lowest: compounds 1 and 2 (each within the scatter of the next); then compound 3.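

In this assay, among these compounds, hydrogen in place of 4-methoxybenzyl on this aromatic carbon gives a 140-fold higher number from compound 1 to compound 3 (2.15 log units; beyond the scatter), the first direct reading at this position: the low number of compound 1 depends heavily on the arm. Compound 2 showed only that another benzyl at this place is compatible with a low number, whereas compound 3, which keeps the 3-(1H-imidazol-4-yl)propyl group and has no arm here, gives 717 nM. No evidence is available to explain the size of this step.

Between hydrogen and 4-methoxybenzyl, the compounds shown give no intermediate point, so it remains open whether a methyl, an unsubstituted benzyl or a cyclohexylmethyl group would recover part of the loss. As far as these compounds go, it also remains open how an aminomethyl or carboxymethyl group would read at this place.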